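Furan-2-yl for phenyl on the shared core

The source may hold more compounds than are shown below. What is called first, only, known or untested is meant among the compounds shown, and "the series" means these compounds.

Compound 2 `COc1nc(N)nc2c1c(-c1ccccc1)cn2[C@@H]1O[C@H](CO)[C@@H](O)[C@H]1O` carries a phenyl group on its core. In an ADME assay on BJ cells (Homo sapiens), read by MTT assay, with a stated time of 72 h (a higher number here means a weaker inhibitor, a lower number a stronger inhibitor), compound 2 gives > 100000 nM, a limit of the assay and not a number. Compound 3 `Nc1nc(N)c2c(-c3ccccc3)cn([C@@H]3O[C@H](CO)[C@@H](O)[C@H]3O)c2n1` gives > 100000 nM in this assay, likewise a limit. For the measured compounds named here, the only step measured in one place, a step that the two limits leave unreadable from compound 2 to compound 3, therefore cannot be read because of the limit of > 100000 nM in this assay, at which 2 of the 3 values shown sit. Going by the values given here, compound 1 `COc1ncnc2c1c(-c1cccs1)cn2[C@@H]1O[C@H](CO)[C@@H](O)[C@H]1O`, with a thiophen-2-yl group and no amino group, gives 62800 nM in this assay as a true number, but no single-change step connects it to compound 2.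

Compound 4 `COc1nc(N)nc2c1c(-c1ccco1)cn2[C@@H]1O[C@H](CO)[C@@H](O)[C@H]1O` is not yet measured. It differs from compound 2 by furan-2-yl in place of phenyl on an aromatic carbon. Among the compounds with values here, no measured step bears on this change; the one step shown sits entirely at the limit. With both neighbours of compound 2 at or near the limit, weak inhibition is expected to persist. For compound 4 the estimated value in this assay is 100000 nM, with a range from 40000 nM to 300000 nM. The estimate implies a step of a number no higher from compound 2 to compound 4 (the limit leaves the size open), expected to lie within the scatter, and a limit is again the likely outcome.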

Compound 4, half-maximal inhibitory concentration: > 100000 nM
Compound 4: only a limit was reported; the forecaster's own chance of this, stated with the estimate: 75%; the middle value lies on the limit itself.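

Compound 2 and compound 4 both sit at a limit of the assay, so the change from phenyl to furan-2-yl yields no readable step, because the reading stops there: the limit of > 100000 nM in this assay, at which 3 of the 4 values shown sit.

The compounds shown leave open how far furan-2-yl and phenyl differ on the shared core in this assay.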